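Trimming the diphenylmethyl group: compound 2 to compound 3

A few compounds are considered here, and "the series" means these few. Any claim that something is new, unique, unknown or untested is made for them only; others in the source may bear on it.

Compound 1 `O=[N+]([O-])c1ccc(OCc2cn(C(c3ccccc3)c3ccccc3)nn2)cc1`: 11600 nM
Compound 2 `c1ccc(-c2ccc(OCc3cn(C(c4ccccc4)c4ccccc4)nn3)cc2)cc1`: 15500 nM

In an assay on isolated protein for inhibition of Aromatase (Homo sapiens), read by fluorescence and colorimetric assay, with a stated time of 30 min (a lower number here means a stronger inhibitor, a higher number a weaker inhibitor), compound 2 gives 15500 nM, the highest of the two numbers measured, yet the step of a 1.3-fold higher number from compound 1 to compound 2 (0.13 log units; within the scatter) is within the scatter, so nothing separates the two. Compound 3 `c1ccc(Cn2cc(COc3ccc(-c4ccccc4)cc3)nn2)cc1` differs from compound 2 by hydrogen in place of phenyl on a saturated chain carbon bound to an aromatic carbon and an aromatic nitrogen. Within the data shown here, no measured step touches this position, so no basis exists for predicting a direction. Compound 3 is therefore estimated near compound 2, with a step of a 1.2-fold higher number from compound 2 to compound 3 (0.06 log units; within the scatter) that is expected to stay within the scatter, at about 18000 nM (range 6000 nM to 55000 nM).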

Compound 3, half-maximal inhibitory concentration: 10700 nM
Compound 3: the middle estimate sits 1.7-fold (0.23 log units) above what was measured; the measured number falls inside the stated range.
By their numbers in this assay, from the lowest: compounds 3, 1 and 2 (each within the scatter of the next).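

Putting hydrogen in place of phenyl on the saturated chain carbon bound to an aromatic carbon and an aromatic nitrogen gives a 1.4-fold lower number from compound 2 to compound 3 (0.16 log units; within the scatter) in this assay. Among these compounds, the earlier step concerned a different place, so this is the first sign that this phenyl, with its 6 heavy atoms, can go without a difference the measurement can separate from scatter. No supporting measurement offers an explanation for this result.

Going by these compounds, whether an amine, a carboxylic acid or a longer chain at this place would move the number beyond the scatter remains open. So does whether the same swap would give a similar result with the nitro group of compound 1 present.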